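Compound 4: losing the tert-butoxycarbonyl group

The source may hold more compounds than are shown below. What is called first, only, known or untested is meant among the compounds shown, and "the series" means these compounds.

- Compound 1 `CN1CCc2c(sc(NC(=O)Nc3ccc(Cl)cc3)c2C(N)=O)C1`: 4700 nM
- Compound 2 `NC(=O)c1c(NC(=O)Nc2ccc(Cl)cc2)sc2c1CCN(C1CCOCC1)C2`: 2830 nM
- Compound 3 `CC(C)(C)OC(=O)CN1CCc2c(sc(NC(=O)Nc3ccc(Cl)cc3)c2C(N)=O)C1`: > 25000 nM, a limit of the assay and not a number

In a functional assay (strain AB) with Danio rerio as the target, read by microscopy, with a stated time of 1 h (a lower number here means that less compound is needed, a higher number that more compound is needed for the effect), compound 3 gives no number, only (the limit of > 25000 nM in this assay, at which 1 of the 3 values shown sits).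

Compound 4 `COCCCN1CCc2c(sc(NC(=O)Nc3ccc(Cl)cc3)c2C(N)=O)C1` has not yet been measured. It carries 2-methoxyethyl in place of tert-butoxycarbonyl on a saturated chain carbon bound to an amine nitrogen in a ring. Put another way, (tert-butoxycarbonyl)methyl gives way to 3-methoxypropyl.

Among the compounds with values here, three measured steps bear on this change. Oxan-4-yl in place of methyl gave a 1.7-fold lower number from compound 1 to compound 2 (0.22 log units; within the scatter). Tert-butoxycarbonyl in place of hydrogen on the chain carbon gave an at least 5.3-fold higher number from compound 1 to compound 3 (0.72 log units; beyond the scatter), and (tert-butoxycarbonyl)methyl in place of oxan-4-yl gave an at least 8.8-fold higher number from compound 2 to compound 3 (0.94 log units; beyond the scatter).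

Compound 4 lacks the tert-butoxycarbonyl group, so it is expected to read like compound 1 at 4700 nM and compound 2 at 2830 nM, not like compound 3. The expected step, toward a lower number in this assay, is an at least 5.5-fold lower number from compound 3 to compound 4 (0.74 log units; beyond the scatter). Within the data shown here, no measured compound carries 3-methoxypropyl, so the range is kept wide. For compound 4 the estimate is 4500 nM, with an expected range of 1500 nM to 15000 nM.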

Compound 4, half-maximal effective concentration: 2400 nM
The estimate for compound 4 lay 1.9-fold (0.27 log units) above the measured number, and the stated range covers the measured number.
By their numbers in this assay, from the lowest: compounds 4, 2 and 1 (each within the scatter of the next). At a limit, above all of these: compound 3.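

In this assay, 2-methoxyethyl in place of tert-butoxycarbonyl on a saturated chain carbon bound to an amine nitrogen in a ring gives a large step (an at least 10-fold lower number from compound 3 to compound 4 (1.01 log units; beyond the scatter)), so this chain carbon can carry a substituent without the loss seen with compound 3. Within the data shown here, compound 4 also stays level with both earlier compounds (a 1.2-fold lower number from compound 2 to compound 4 (0.07 log units; within the scatter); a 2.0-fold lower number from compound 1 to compound 4 (0.29 log units; within the scatter)), which places 3-methoxypropyl on the amine nitrogen in a ring alongside methyl and oxan-4-yl, and leaves the tert-butoxycarbonyl group as the one change here tied to a step beyond the scatter. The reading for compound 3 remains a limit of the assay and not a number: the limit of > 25000 nM in this assay, at which 1 of the 4 values shown sits.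

Open, on these data alone, is whether the whole tert-butoxycarbonyl group or only part of it goes with that loss, a question that a carboxylic acid or a primary amide on the same chain carbon would address. Also open, as far as these compounds go, is whether any group at this place, such as a longer chain ending in methoxy or an amine, would move the number beyond the scatter from the level of compounds 1, 2 and 4.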